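Rearranging the Dithiocarbamate Side Chain of Compound 2

The source may hold more compounds than are shown below. What is called first, only, known or untested is meant among the compounds shown, and "the series" means these compounds.

Compound 2 `COc1cc(/C=C/C(=O)c2ccc(OCCSC(=S)N3CCCCC3)cc2)cc(OC)c1OC` gives 38900 nM in a functional assay on ECa-109 cells for inhibition, with ECa-109 cell line (Homo sapiens) as the target, read by MTT assay, with a stated time of 72 h (a lower number here means a stronger inhibitor, a higher number a weaker inhibitor), the highest of the three numbers recorded so far, although compound 3 `O=C(/C=C/c1ccc(Cl)cc1)c1ccc(OCCSC(=S)N2CCCC2)cc1` sits within the scatter of it at 27800 nM. Compound 1 `COc1cc(/C=C/C(=O)c2ccc(OCCSC(=S)N3CCCC3)cc2)cc(OC)c1OC` lies further off at 10700 nM. For the measured compounds named here, the only single-point step among the measured compounds is a 3.6-fold higher number from compound 1 to compound 2 (0.56 log units; beyond the scatter). Compound 4 `COc1cc(/C=C/C(=O)c2ccc(OCCCSC(=S)N3CCCC3)cc2)cc(OC)c1OC` has the same atoms as compound 2, joined differently: a group of 9 heavy atoms (6 carbon, 1 nitrogen, 2 sulfur; one five-membered non-aromatic ring with 1 hetero atom) in place of a group of 9 heavy atoms (6 carbon, 1 nitrogen, 2 sulfur; one six-membered non-aromatic ring with 1 hetero atom), on a saturated chain carbon, two bonds along the chain from an oxygen on an aromatic ring. This restores the five-membered non-aromatic ring found in compound 1, so that measured step bears on the change in reverse, even though the two changes are not identical and the expectation is correspondingly loose. Compound 4 is therefore expected to move back toward where compound 1 stands, an estimated 3.2-fold lower number from compound 2 to compound 4 (0.51 log units; beyond the scatter). Compound 4 is estimated at 12000 nM, with a range from 5000 nM to 30000 nM.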

Compound 4, half-maximal inhibitory concentration: 11100 nM
Compound 4: middle estimate off by 1.1-fold (0.03 log units), on the high side; measured number inside the range.
By their numbers in this assay, from the lowest: compounds 1 and 4 (each within the scatter of the next); then compounds 3 and 2 (each within the scatter of the next).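

In this assay, the same atoms joined differently give a 3.5-fold lower number from compound 2 to compound 4 (0.54 log units; beyond the scatter), so at this place, on a saturated chain carbon, two bonds along the chain from an oxygen on an aromatic ring, the two isomeric groups are not interchangeable. Going from the group of compound 1 to the group of 9 heavy atoms, both with the five-membered ring, gives a 1.0-fold higher number from compound 1 to compound 4 (0.02 log units; within the scatter), so on the core of compound 1 the larger group costs nothing measurable while the five-membered ring is kept. Nothing available explains why these groups differ in this way.

As far as these compounds go, whether the same holds on the core of compound 3 remains open. So does the outcome for a morpholin-4-yl ring on the thiocarbonyl carbon, or for a longer chain.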